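The source may report more compounds than this note shows. Statements on the series, on what has been measured and on what is new or still open speak of the compounds shown alone.

a functional assay on HT-29 cells (Homo sapiens) for inhibition, read by luminescence and CellTiter-Glo, with a stated time of 24 h (a higher number here means that more compound is needed for the effect, a lower number that less compound is needed), measured so far:
compound 1 `CN1C(=S)[C@@H](NC(=O)c2nc(Cc3ccccc3)n(CCCC(F)(F)F)n2)COc2ccccc21`: 2380 nM
compound 2 `CN1C(=S)[C@@H](NC(=O)c2nc(Cc3ccccc3)n(CC3CCOCC3)n2)COc2ccccc21`: 6310 nM

Of these two, compound 2 has the higher number, 6310 nM, so more of it is needed for the effect. The next structure, compound 3 `CN1C(=S)[C@@H](NC(=O)c2nc(Cc3ccccc3)n(C3CCNC3)n2)COc2ccccc21`, changes one group: pyrrolidin-3-yl in place of (oxan-4-yl)methyl on an aromatic nitrogen. In words, pyrrolidin-3-yl takes the place of (oxan-4-yl)methyl on an aromatic nitrogen. Going by the values given here, only one measured step bears on this, and it too alters what sits on that aromatic nitrogen. It is modest: a 2.7-fold higher number from compound 1 to compound 2 (0.42 log units; beyond the scatter). A single step is thin evidence, and neither measured group is a pyrrolidin-3-yl. In this assay, among the compounds with values here, a small move toward a higher number is expected, no larger than that step and perhaps within the scatter. The expected change is a 1.4-fold higher number from compound 2 to compound 3 (0.15 log units; within the scatter). The estimate for compound 3 is 9000 nM, with an expected range of 3000 nM to 30000 nM.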

Compound 3, half-maximal effective concentration: 1070 nM
The estimate for compound 3 lay 8.4-fold (0.92 log units) above the measured number, outside the stated range (below it).
By their numbers in this assay, from the lowest: compound 3; then compound 1; then compound 2.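

In this assay, the group on this aromatic nitrogen can lower the number as well as raise it: the change gives a 5.9-fold lower number from compound 2 to compound 3 (0.77 log units; beyond the scatter), and the trifluorinated chain gives way with a 2.2-fold lower number from compound 1 to compound 3 (0.35 log units; beyond the scatter). Going by these compounds alone, compound 3 has the lowest number of the three, and it is the only one whose group carries a hydrogen-bond donor, though three compounds cannot establish that as a pattern. No measurement shown here accounts for the drop.

The swap from (oxan-4-yl)methyl to pyrrolidin-3-yl alters the ring size, the ring hetero atom and the methyl link all at once, so the compounds shown cannot say which of these matters. A piperidin-4-yl group or an open-chain aminoethyl group on the same nitrogen would help separate these changes.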